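A few compounds are considered here, and "the series" means these few. Any claim that something is new, unique, unknown or untested is made for them only; others in the source may bear on it.

Among the compounds with values here, compound 3 `CC(C)(C)n1ncc(OCc2nnc(-c3cc(F)c(F)cc3F)o2)c(Cl)c1=O` is the one member of this set with a number in a functional assay on the whole organism for inhibition, with Mythimna separata as the target, with a stated time of 5 days (on this read-out lower numbers stand for an effect already at smaller amounts and higher numbers for an effect only at larger amounts of compound), where compound 3 gives 75700 nM. Compound 1 `COc1c(F)c(F)cc(-c2nnc(COc3cnn(C(C)(C)C)c(=O)c3Cl)o2)c1F` reaches only the limit of > 299000 nM in this assay. Compound 2 `Cc1cc(C)cc(-c2nnc(COc3cnn(C(C)(C)C)c(=O)c3Cl)s2)c1` likewise reaches only the limit of > 299000 nM in this assay. Within the data shown here, the single measured step, an at least 3.9-fold lower number from compound 1 to compound 3 (0.59 log units; beyond the scatter), is itself a lower bound because compound 1 sits at the limit of > 299000 nM in this assay, at which 2 of the 3 values shown sit. Compound 4 `CCc1ccc(-c2nnc(COc3cnn(C(C)(C)C)c(=O)c3Cl)o2)cc1` differs from compound 3 by 4-ethylphenyl in place of 2,4,5-trifluorophenyl on an aromatic carbon. Among the measured compounds shown here, no measured step covers such a change of the aryl group. Compound 4 is therefore expected to give roughly 200000 nM in this assay, within 60000 nM to 600000 nM, a step of a 2.6-fold higher number from compound 3 to compound 4 (0.42 log units; beyond the scatter) toward a weaker effect, with a real chance that only a limit is reported.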

Compound 4, half-maximal effective concentration: 14500 nM
Estimate against measurement, compound 4: 14-fold (1.14 log units) above, outside the stated range (below it).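

On an aromatic carbon of the five-membered ring, 4-ethylphenyl in place of 2,4,5-trifluorophenyl gives a 5.2-fold lower number from compound 3 to compound 4 (0.72 log units; beyond the scatter) in this assay. This position therefore carries an aryl group without fluorine and still gives a number, and this step joins two real numbers, unlike the earlier step, which is only a bound set by a limit: the limit of > 299000 nM in this assay, at which 2 of the 4 values shown sit.

The compounds shown leave open whether the ethyl group or the loss of the three fluorines carries the step. They also leave open how 4-butylphenyl or an aminophenyl group would read at this position.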